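From compound 2 to compound 4: a changed amide

A few compounds are considered here, and "the series" means these few. Any claim that something is new, unique, unknown or untested is made for them only; others in the source may bear on it.

Measured in a functional assay on L6 cells (Rattus norvegicus) for inhibition; on this read-out lower numbers stand for stronger inhibition and higher numbers for weaker inhibition:
- compound 1 `CC(C)c1c(C(=O)N(C)Cc2cccc(F)c2)nn(-c2ccc(F)cc2)c1CC[C@@H](O)C[C@@H](O)CC(=O)O` gives 1900 nM
- compound 2 `CC(C)c1c(C(=O)NCc2cccc(F)c2F)nn(-c2ccc(F)cc2)c1OC[C@@H](O)C[C@@H](O)CC(=O)O` gives 120 nM
- compound 3 `CC(C)c1c(C(=O)N2CCC[C@H](N3CCC4C=CC=CC4C3)C2)nn(-c2ccc(F)cc2)c1CC[C@@H](O)C[C@@H](O)CC(=O)O` gives 1720 nM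

Compound 2 has the lowest number of the three, and both other compounds stand beyond the scatter from it. Among the measured compounds shown here, no two measured compounds differ in one place only, so the series shows no direct effect of any single change.

The next compound is compound 4 `CC(C)c1c(C(=O)N2CCC[C@H](c3ccccc3)C2)nn(-c2ccc(F)cc2)c1OC[C@@H](O)C[C@@H](O)CC(=O)O`, which differs from compound 2 as follows: 3-phenylpiperidin-1-yl in place of (2,3-difluorobenzyl)amino on a carbonyl carbon. In words, 3-phenylpiperidin-1-yl stands in place of (2,3-difluorobenzyl)amino on a carbonyl carbon, and the amide hydrogen is gone.

Compound 1 at 1900 nM and compound 3 at 1720 nM also lack that hydrogen, but both differ from compound 2 elsewhere as well, so they are only weak guides. Compound 4 keeps the rest of compound 2 at 120 nM, which argues against expecting the full gap.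

In this assay a step towards weaker inhibition is expected, estimated as a 5.8-fold higher number from compound 2 to compound 4 (0.77 log units; beyond the scatter) and likely beyond the scatter. For compound 4 the estimate is 700 nM as the expected value, with an expected range from 200 nM to 2500 nM given the thin evidence.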

Compound 4, half-maximal inhibitory concentration: 1110 nM
Beside the measured number, compound 4's estimate is 1.6-fold (0.20 log units) below it, within the range that was stated.
By their numbers in this assay, from the lowest: compound 2; then compounds 4, 3 and 1 (each within the scatter of the next).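

In this assay, among the compounds shown here, the swap of (2,3-difluorobenzyl)amino for 3-phenylpiperidin-1-yl on the carbonyl carbon gives a 9.3-fold higher number from compound 2 to compound 4 (0.97 log units; beyond the scatter), towards weaker inhibition, and this is the first single-place step, so the group on this carbonyl carbon clearly affects the read-out while the rest of the structure stays fixed. The step bundles several differences: the amide hydrogen and both fluorines leave, while a six-membered non-aromatic ring and a defined stereocentre enter, and this one pair cannot assign the loss to any one of them. No measurement at hand bears on the reason for the rise in the number.

Still open, as far as these compounds go, is whether the loss follows the amide hydrogen or the shape of the new group: an N-methyl-N-(2,3-difluorobenzyl)amino group would remove the hydrogen and keep the benzyl group, whereas plain benzylamino would isolate the two fluorines. The opposite enantiomer of the 3-phenylpiperidin-1-yl group and an unsubstituted piperidin-1-yl group would likewise show whether the stereocentre and the phenyl ring matter at this position.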